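The source may hold more compounds than are shown below. What is called first, only, known or untested is meant among the compounds shown, and "the series" means these compounds.

- compound 1 `N#Cc1ccc(O[C@H]2CN(S(=O)(=O)c3ccc(C(F)(F)F)cc3)C[C@@]2(O)CO)cc1F`: 5.9 L/kg
- compound 2 `N#Cc1ccc(O[C@H]2CN(S(=O)(=O)c3ccc(Cl)cc3)C[C@@]2(O)CO)cc1F`: 6 L/kg

In an ADME assay on the whole organism (Rattus norvegicus, strain Sprague-Dawley) for pharmacokinetics, read by LC-MS, with a stated time of 30 min (on this read-out lower numbers stand for narrower distribution and higher numbers for wider distribution into tissues), compound 2 gives 6 L/kg, which lies within the scatter of compound 1. Compound 3 `N#Cc1ccc(O[C@H]2CN(S(=O)(=O)c3ccc(C(F)(F)F)nc3)C[C@@]2(O)CO)cc1F` carries 6-(trifluoromethyl)pyridin-3-yl in place of 4-chlorophenyl on a sulfonyl sulfur. Among the measured compounds shown here, the only measured step, a 1.0-fold higher number from compound 1 to compound 2 (0.01 log units; within the scatter), has chloro in place of trifluoromethyl on an aromatic carbon and stays within the scatter. For the measured compounds named here, no measured step covers the change to a ring with a hetero atom, so that part remains open. The expected change is a 1.3-fold lower number from compound 2 to compound 3 (0.12 log units; within the scatter), with no step beyond the scatter. For compound 3 the estimated value is 4.5 L/kg, with an expected range of 2.5 L/kg to 8 L/kg.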

Compound 3, volume of distribution at steady state: 4.1 L/kg
Beside the measured number, compound 3's estimate is 1.1-fold (0.04 log units) above it, and the stated range covers the measured number.
By their numbers in this assay, from the lowest: compounds 3, 1 and 2 (each within the scatter of the next).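

On the sulfonyl sulfur, 6-(trifluoromethyl)pyridin-3-yl gives a 1.5-fold lower number from compound 2 to compound 3 (0.17 log units; within the scatter) in this assay and a 1.4-fold lower number from compound 1 to compound 3 (0.16 log units; within the scatter) against 4-(trifluoromethyl)phenyl. Among the compounds shown here, a ring with a hetero atom at this position, absent from the earlier compounds, thus stays within the scatter of both carbon-only rings. Nothing measured here gives a reason for this. From the compounds shown here alone, whether an amine or a carboxylic acid in place of these rings on the sulfonyl sulfur would give a step beyond the scatter remains open. So does the effect of any change elsewhere on the shared core.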